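This account rests on a few compounds, and the source may have more. Where it says the series, first, only, none or still open, it means among the compounds named here.

Compound 1 `CC1CCN(c2c(S(=O)(=O)c3ccc(Cl)cc3)cnc3ccc(Cl)cc23)CC1` and compound 2 `CC1CCN(c2c(S(=O)(=O)c3cc(Cl)cc(Cl)c3)cnc3ccc(Cl)cc23)CC1` share one core and differ only in the aryl group on the sulfonyl sulfur. In an assay on isolated protein for displacement of a labelled ligand from metabotropic glutamate receptor 5 (Homo sapiens), with a stated time of 60 min, tested at 1 uM (on this read-out lower numbers stand for less inhibition and higher numbers for more inhibition at the one concentration tested (going by the name of the read-out)), compound 1 gives 92%; compound 2 gives 88%. Among the measured compounds shown here, the single step on record, a number 4 percentage points lower from compound 1 to compound 2 (within the scatter), is within the scatter, so compound 2 stands level with compound 1 on this read-out. Compound 3 `CC1CCN(c2c(S(=O)(=O)c3ccc(C#N)cc3)cnc3ccc(Cl)cc23)CC1` carries 4-cyanophenyl in place of 3,5-dichlorophenyl on a sulfonyl sulfur. For the measured compounds named here, only that one step bears on the change, and it stayed within the scatter, so no step beyond the scatter is expected in this assay. Compound 3 is estimated at 85%, with a range of 70% to 96%, an expected step of a number 3 percentage points lower from compound 2 to compound 3 (within the scatter).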

Compound 3, a percentage reported as inhibition, at one concentration (the size of the read-out at that concentration, not a potency): 31%
The estimate for compound 3 lay 54 percentage points above the measured number; the measured number lies below the stated range.
By their numbers in this assay, from the lowest: compound 3; then compounds 2 and 1 (each within the scatter of the next).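

The aryl group on the sulfonyl sulfur is not a free choice in this assay: 4-cyanophenyl in place of 3,5-dichlorophenyl gives a number 57 percentage points lower from compound 2 to compound 3 (beyond the scatter), and cyano in place of chloro on an aromatic carbon gives a number 61 percentage points lower from compound 1 to compound 3 (beyond the scatter). The two chlorinated aryl groups alone gave no sign of this sensitivity, which appears only with the nitrile. Nothing available explains the drop.

Still open, on these data alone, is whether a methyl or methoxy group in place of chloro on this aromatic carbon keeps the inhibition seen with chloro. A carboxylic acid or an amine there is equally untested by the compounds shown.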